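From compound 2 to compound 3: one more chloro

This account rests on a few compounds, and the source may have more. Where it says the series, first, only, none or still open, it means among the compounds named here.

Compound 1 `CC(=O)Nc1ccc(/C=C/C(=O)c2ccc3c(c2O)C=CC(C)(C)O3)cc1`: 279000 nM
Compound 2 `CC1(C)C=Cc2c(ccc(C(=O)/C=C/c3ccc(Cl)cc3)c2O)O1`: 92200 nM

In an ADME assay on Vero cells (Chlorocebus sabaeus) for cytotoxicity, read by MTT assay, with a stated time of 72 h (a higher number here means that more compound is tolerated, a lower number that less compound is tolerated), compound 2 gives 92200 nM, the lower of the two numbers. Compound 3 `CC1(C)C=Cc2c(ccc(C(=O)/C=C/c3ccc(Cl)cc3Cl)c2O)O1` carries one change from compound 2: chloro in place of hydrogen on an aromatic carbon. This is chloro in place of hydrogen on an aromatic carbon, turning 4-chlorophenyl into 2,4-dichlorophenyl. Within the data shown here, only one measured step bears on it, the modest 3.0-fold lower number from compound 1 to compound 2 (0.48 log units; beyond the scatter), and that step exchanged a different group. A small move to a lower number is therefore expected, perhaps none beyond the scatter, and the expected step is a 1.4-fold lower number from compound 2 to compound 3 (0.15 log units; within the scatter). For compound 3 the estimate is 65000 nM, with an expected range of 27000 nM to 140000 nM.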

Compound 3, half-maximal cytotoxic concentration: 131000 nM
For compound 3 the middle estimate is 2.0-fold (0.30 log units) below the measured one; measured number inside the range.
By their numbers in this assay, from the lowest: compounds 2 and 3 (each within the scatter of the next); then compound 1.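

In this assay, adding chloro ortho to a large group and meta to a chloro group gives a 1.4-fold higher number from compound 2 to compound 3 (0.15 log units; within the scatter) and so leaves no difference beyond the scatter. Turning 4-chlorophenyl into 2,4-dichlorophenyl therefore does not shift the number in the way that replacing acetamido with chloro did. Nothing measured here accounts for this result.

On these data alone, whether a methoxy group or an amine on this same aromatic carbon would also stay within the scatter of compound 2 remains open. So does whether this added chloro would behave alike with the acetamido group of compound 1 in place of the first chloro.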